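Lengthening a Methyl to Ethyl on Compound 2

A few compounds are considered here, and "the series" means these few. Any claim that something is new, unique, unknown or untested is made for them only; others in the source may bear on it.

Compound 1 `CC1CCC(=NNc2ccccc2)c2ncc(C(=O)O)c(=O)n21` gives 1.2 umol/kg in a functional assay on the whole organism with Rattus norvegicus as the target; on this read-out lower numbers stand for an effect already at smaller amounts and higher numbers for an effect only at larger amounts of compound. Compound 2 `Cc1nc2n(c(=O)c1C(=O)O)C(C)CCC2=NNc1ccccc1` carries a methyl in place of hydrogen on an aromatic carbon, and this gives an at least 260-fold higher number from compound 1 to compound 2 (2.42 log units; beyond the scatter). For compound 2 the reading in this assay is only a limit of the assay, > 320 umol/kg, so its true number is not known. Compound 3 `CCc1nc2n(c(=O)c1C(=O)O)C(C)CCC2=NNc1ccccc1` differs from compound 2 by methyl in place of hydrogen on a saturated chain carbon bound to an aromatic carbon. Within the data shown here, no measured step matches this change; the one known step, an at least 260-fold higher number from compound 1 to compound 2 (2.42 log units; beyond the scatter), sits at a different place and went in the losing direction, and compound 2 already stands at the limit of > 320 umol/kg in this assay, at which 1 of the 2 values shown sits. Adding a further carbon is thus not expected to bring the effect back, and the change is expected to read a step that the limit leaves unreadable from compound 2 to compound 3. Compound 3 is estimated at 500 umol/kg, with a range from 100 umol/kg to 3000 umol/kg, and most likely the assay again reports only a limit.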

Compound 3, dose for 50% inhibition: > 320 umol/kg
Compound 3 ended at the assay's limit (the forecaster's own chance of this, stated with the estimate: 85%); the middle value is on the limit's open side.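

In this assay, compound 3 reads only as a limit, > 320 umol/kg. The step from methyl to ethyl cannot be read, so this position gives no sign of whether the longer chain changes the effect at all; what can be read is hydrogen giving way to ethyl on the aromatic carbon, which gives an at least 260-fold higher number from compound 1 to compound 3 (2.42 log units; beyond the scatter), so the loss seen with methyl holds for ethyl too. Both compounds with a chain on that aromatic carbon now share a single reading: the limit of > 320 umol/kg in this assay, at which 2 of the 3 values shown sit.

Both groups shown on that carbon are carbon chains, so it stays open whether an amine, a hydroxyl or a fluorine there would keep the effect of compound 1. As far as these compounds go, the true numbers of compound 2 and compound 3 also stay open.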